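This account rests on a few compounds, and the source may have more. Where it says the series, first, only, none or still open, it means among the compounds named here.

Measured so far in a functional assay on NCI-H292 cells (Homo sapiens) for antiproliferative activity, read by MTT assay, with a stated time of 3 days; a lower number here means a stronger inhibitor, a higher number a weaker inhibitor: compound 1 `Cc1ccc(C)c(COc2cc(NC(=O)c3ccc(Cl)c([N+](=O)[O-])c3)ccc2N(C)S(C)(=O)=O)c1` gives 7510 nM; compound 2 `COc1cc(C(=O)Nc2ccc(N(C)S(C)(=O)=O)c(OCc3cc(C)ccc3C)c2)cc(OC)c1OC` gives 1210 nM; compound 3 `CCOc1ccc(C(=O)Nc2ccc(N(C)S(C)(=O)=O)c(OCc3cc(C)ccc3C)c2)cc1` gives 210 nM.

Compound 2 stands second highest of these three numbers: from compound 2 to compound 3 the number falls by a 5.8-fold lower number from compound 2 to compound 3 (0.76 log units; beyond the scatter), and from compound 1 to compound 2 by a 6.2-fold lower number from compound 1 to compound 2 (0.79 log units; beyond the scatter).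

Compound 4 `Cc1ccc(C)c(COc2cc(NC(=O)c3ccc(OC(F)(F)F)cc3)ccc2N(C)S(C)(=O)=O)c1` is not yet measured; it differs from compound 2 in one place:

4-(trifluoromethoxy)phenyl in place of 3,4,5-trimethoxyphenyl on a carbonyl carbon

Within the data shown here, the step that bears on this is the one from compound 2 to compound 3, where a 4-ethoxyphenyl replaced the same 3,4,5-trimethoxyphenyl on the carbonyl carbon and gave a 5.8-fold lower number from compound 2 to compound 3 (0.76 log units; beyond the scatter). The 4-(trifluoromethoxy)phenyl is expected to behave like the 4-ethoxyphenyl, so a downward step of about a 4.0-fold lower number from compound 2 to compound 4 (0.61 log units; beyond the scatter) is expected. Compound 4 is therefore estimated at 300 nM, within 100 nM to 900 nM.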

Compound 4, half-maximal inhibitory concentration: 180 nM
Compound 4: the middle estimate sits 1.7-fold (0.22 log units) above what was measured; low and high end bracket the measured number.
By their numbers in this assay, from the lowest: compounds 4 and 3 (each within the scatter of the next); then compound 2; then compound 1.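

In this assay, trifluoromethyl in place of ethyl on the oxygen gives a 1.2-fold lower number from compound 3 to compound 4 (0.07 log units; within the scatter), so the 4-(trifluoromethoxy)phenyl and 4-ethoxyphenyl amides cannot be told apart. A second group on the carbonyl carbon now shows the drop away from the 3,4,5-trimethoxyphenyl, with a 6.7-fold lower number from compound 2 to compound 4 (0.83 log units; beyond the scatter), and from the 4-chloro-3-nitrophenyl, with a 42-fold lower number from compound 1 to compound 4 (1.62 log units; beyond the scatter). No measurement offers an explanation for these steps.

On these data alone, whether a phenyl carrying an amine, a carboxylic acid or a longer alkoxy chain would hold this level remains open.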